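Swapping the Terminal Amine at the End of a Butyl Chain

This account rests on a few compounds, and the source may have more. Where it says the series, first, only, none or still open, it means among the compounds named here.

Measured so far:
compound 1, `O=C1c2c[n+]([O-])c3ccccc3c2C(=O)c2c1c1ccccc1n2Cc1cn([C@H]2O[C@H](CO)[C@@H](O)[C@H]2O)nn1`, 1340 nM
compound 2, `O=C1c2c[n+]([O-])c3ccccc3c2C(=O)c2c1c1ccccc1n2CCCCN1CCNCC1`, 1240 nM

In a functional assay on SH-SY5Y cells (Homo sapiens) for cytotoxicity, read by MTT assay, with a stated time of 72 h (a lower number here means a stronger inhibitor, a higher number a weaker inhibitor), compound 1 gives 1340 nM, and compound 2 gives 1240 nM. Compound 2 holds the lowest of the two numbers, but its gap to compound 1 lies within the scatter, so the two stand level. Compound 3, `CN(C)CCCCn1c2c(c3ccccc31)C(=O)c1c[n+]([O-])c3ccccc3c1C2=O`, differs from compound 2 in one place: dimethylamino in place of piperazin-1-yl on a saturated chain carbon, four bonds along the chain from an aromatic nitrogen. Within the data shown here, no measured pair carries this change, so nothing sets its size; the step is expected to be a 1.1-fold higher number from compound 2 to compound 3 (0.05 log units; within the scatter), none beyond the scatter. Compound 3 is estimated at 1400 nM, with a range from 600 nM to 3500 nM.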

Compound 3, half-maximal inhibitory concentration: 250 nM
Compound 3: middle estimate off by 5.6-fold (0.75 log units), on the high side, and the stated range ends above it.
By their numbers in this assay, from the lowest: compound 3; then compounds 2 and 1 (each within the scatter of the next).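

The group at the end of the butyl chain proves to matter in this assay: dimethylamino in place of piperazin-1-yl gives a 5.0-fold lower number from compound 2 to compound 3 (0.70 log units; beyond the scatter) and separates compound 3 from a pair that stood level. Compound 1 and compound 2 alone could not show that this position responds to a change of amine. Nothing available accounts for the size of the step. From the compounds shown here alone, it remains open how diethylamino, pyrrolidin-1-yl or morpholin-4-yl would read at the end of this chain. Going by these compounds, whether dimethylamino on a shorter or longer chain keeps the lower number is also open.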